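The source may report more compounds than this note shows. Statements on the series, on what has been measured and on what is new or still open speak of the compounds shown alone.

In an ADME assay on L02 cells (Homo sapiens) for cytotoxicity, read by CCK-8 assay, with a stated time of 6 days (a higher number here means a weaker inhibitor, a lower number a stronger inhibitor), compound 1 (`C[C@@H](Cn1ccc(-c2ccc(C#N)c(Cl)c2)n1)Nc1ccccc1`) gives 29400 nM. Compound 2 (`C[C@@H](Cn1ccc(-c2ccc(C#N)c(Cl)c2)n1)Nc1cncnc1`) gives > 30000 nM, which is a limit of the assay and not a number. Its place on the scale is therefore known only as this limit. Compound 3 (`C[C@@H](Cn1ccc(-c2ccc(C#N)c(Cl)c2)n1)Nc1ncnc2nc[nH]c12`) differs from compound 2 by a group of 9 heavy atoms (5 carbon, 4 nitrogen; one five-membered aromatic ring with 2 hetero atoms, one six-membered aromatic ring with 2 hetero atoms) in place of a group of 6 heavy atoms (4 carbon, 2 nitrogen; one six-membered aromatic ring with 2 hetero atoms), on an amine nitrogen. The group that enters keeps a six-membered aromatic ring with 2 hetero atoms and adds one five-membered aromatic ring with 2 hetero atoms. Among the measured compounds shown here, one measured step bears on this change, also made on the amine nitrogen: an at least 1.0-fold higher number from compound 1 to compound 2 (0.00 log units; that floor lies within the scatter), with pyrimidin-5-yl in place of phenyl. For the measured compounds named here, with only that step as a guide, no change beyond the scatter is expected in this assay. The expected step is a number no higher from compound 2 to compound 3 (the limit leaves the size open). Compound 3 is estimated at 30000 nM, within a range of 12000 nM to 60000 nM.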

Compound 3, half-maximal inhibitory concentration: 27900 nM
The estimate for compound 3 lay 1.1-fold (0.03 log units) above the measured number; the measured number falls inside the stated range.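

In this assay, the group of 9 heavy atoms on the amine nitrogen changes little: the swap gives an at least 1.0-fold lower number from compound 2 to compound 3 (0.03 log units; that floor lies within the scatter), and against the phenyl group it gives a 1.1-fold lower number from compound 1 to compound 3 (0.02 log units; within the scatter). The amine nitrogen thus takes a larger group with two aromatic rings and 1 hydrogen-bond donor, and no step beyond the scatter appears among the replacements shown. The first of these steps is only a floor, since the value of compound 2 is a limit of the assay and not a number: the limit of > 30000 nM in this assay, at which 1 of the 3 values shown sits.

From the compounds shown here alone, whether any group on this amine nitrogen can move the number beyond the scatter stays open, for example a saturated piperidine ring or a chain ending in a carboxylic acid. Going by these compounds, how far the true value of compound 2 lies past its limit also remains unknown.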